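Fluoro on the bromophenyl of a pyridinone amide series

A few compounds are considered here, and "the series" means these few. Any claim that something is new, unique, unknown or untested is made for them only; others in the source may bear on it.

Two compounds of the series have a number in a functional assay on MCF7 cells (Homo sapiens) for cytotoxicity, read by MTT assay, with a stated time of 72 h; a higher number here means a weaker inhibitor, a lower number a stronger inhibitor. Compound 1, `O=C(Nc1ccc(Oc2ccnc3[nH]ccc23)cc1)c1nn(-c2ccc(Br)cc2F)ccc1=O`, gives 17900 nM. Compound 2, `O=C(Nc1ccc(Oc2ccnc3[nH]ccc23)c(F)c1)c1nn(-c2ccc(Br)cc2)ccc1=O`, gives 11600 nM. Compound 2 has the lowest of the two numbers; its nearest neighbour is compound 1, whose number is higher, a gap that lies within the scatter of repeated measurements, so no order between the two can be read from this pair.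

Compound 3, `O=C(Nc1ccc(Oc2ccnc3[nH]ccc23)c(F)c1)c1nn(-c2ccc(Br)cc2F)ccc1=O`, is not yet measured in this assay. It differs from compound 2 in one place: fluoro in place of hydrogen on an aromatic carbon. Compound 1 already carries the 4-bromo-2-fluorophenyl group, and its number in this assay does not stand apart from that of compound 2. Among the compounds with values here, no step between measured compounds is available for this exact change. The step from compound 2 to compound 3 is therefore expected to be a 1.1-fold higher number from compound 2 to compound 3 (0.05 log units; within the scatter), nothing beyond the scatter in either direction. For compound 3 a value of 13000 nM is estimated, within a range of 5000 nM to 35000 nM.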

Compound 3, half-maximal inhibitory concentration: 23500 nM
The estimate for compound 3 lay 1.8-fold (0.26 log units) below the measured number; low and high end bracket the measured number.
By their numbers in this assay, from the lowest: compounds 2, 1 and 3 (each within the scatter of the next, the first and the last beyond it).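

In this assay, the change from 4-bromophenyl to 4-bromo-2-fluorophenyl can now be read directly, and it gives a 2.0-fold higher number from compound 2 to compound 3 (0.31 log units; beyond the scatter), a modest step in the direction of a weaker inhibitor. The other fluoro, which compound 3 shares with compound 2 and which compound 1 lacks, gives a 1.3-fold higher number from compound 1 to compound 3 (0.12 log units; within the scatter), so in this pair of steps only the fluoro on the bromophenyl group moves the number beyond the scatter, and each change is seen in a single pair. Nothing available explains the step at this position.

As far as these compounds go, whether a group other than fluoro, such as chloro, methoxy or an amine, would shift the number at this carbon remains open. Also open, from the compounds shown here alone, is whether the step holds in a compound without the second fluoro.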